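The source may hold more compounds than are shown below. What is called first, only, known or untested is meant among the compounds shown, and "the series" means these compounds.

Working notes on the series, read in a physicochemical assay for lipophilicity, read by HPLC, at pH 7.5; on this read-out higher numbers stand for higher lipophilicity and lower numbers for lower lipophilicity. Compound 1 `CCCN(CCC)C(=O)Cc1c(-c2ccc(OC)cc2)nn2c(CC)cc(CC)nc12` gives 3.35, compound 2 `CCCCCN(CCCCC)C(=O)Cc1c(-c2ccc(OC)cc2)nn2c(CC)cc(CC)nc12` gives 4.29, and compound 3 `CCc1cc(CC)n2nc(-c3ccc(OC)cc3)c(CC(=O)N(CC)C(C)(C)C)c2n1` gives 3.32. Compound 3 therefore sits with the lower pair: the smaller gap is a number 0.03 log units lower from compound 1 to compound 3 (within the scatter), and the larger is a number 0.97 log units lower from compound 2 to compound 3 (beyond the scatter).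

The change to compound 4 `CCc1cc(CC)n2nc(-c3ccc(OC)cc3)c(CC(=O)N(C(C)CC)C(C)CC)c2n1` is a group of 9 heavy atoms (8 carbon, 1 nitrogen; no ring) in place of a group of 7 heavy atoms (6 carbon, 1 nitrogen; no ring), on a carbonyl carbon, with bis(sec-butyl)amino entering on a carbonyl carbon. Within the data shown here, two steps bear on it. The first is a number 0.94 log units higher from compound 1 to compound 2 (beyond the scatter), with dipentylamino in place of dipropylamino. The second is a number 0.03 log units lower from compound 1 to compound 3 (within the scatter), an exchange of groups with equal counts. The entering group falls in size between the groups of compound 3 and compound 2, so a modest rise smaller in size than a number 0.97 log units lower from compound 2 to compound 3 (beyond the scatter) is expected in this assay. Among the measured compounds shown here, no measured compound carries this branched group, which keeps the range wide. The expected step is a number 0.48 log units higher from compound 3 to compound 4 (beyond the scatter). Compound 4 is estimated at 3.8, with an expected range of 3.5 to 4.1.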

Compound 4, partition coefficient: 3.75
Compound 4: middle estimate off by 0.05 log units, on the high side; measured number inside the range.
By their numbers in this assay, from the lowest: compounds 3 and 1 (each within the scatter of the next); then compound 4; then compound 2.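

At this place on a carbonyl carbon, this assay shows that bis(sec-butyl)amino does not read with the lower pair: the change gives a number 0.40 log units higher from compound 1 to compound 4 (beyond the scatter) and a number 0.43 log units higher from compound 3 to compound 4 (beyond the scatter). Among these compounds, it also stays clear of the top of the series, with a number 0.54 log units lower from compound 2 to compound 4 (beyond the scatter), so the read-out now has three levels, and across these four compounds it follows the heavy-atom count of the group on the carbonyl carbon, with no compound going against that order. Nothing at hand gives a reason for these steps.

The compounds shown leave open whether dibutylamino, the unbranched counterpart of bis(sec-butyl)amino, would read with compound 4. They also leave open whether the same order would hold for a ring amine such as piperidine at this place.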